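Replacing the amine linker of compound 3 by an ether

The source may hold more compounds than are shown below. What is called first, only, known or untested is meant among the compounds shown, and "the series" means these compounds.

Compound 3 `CN(Cc1cccc(C(=O)O)c1)c1ccc(OCc2c(-c3c(Cl)cccc3Cl)noc2C2CC2)nc1C(F)(F)F` is read in an assay on isolated protein for agonist activity at Bile acid receptor (Homo sapiens), read by FRET (on this read-out higher numbers stand for larger maximal responses and lower numbers for smaller maximal responses), where compound 3 gives 102%. For the measured compounds named here, this puts compound 3 level with compound 1 `CC(C)c1onc(-c2c(Cl)cccc2Cl)c1COc1ccc(N(C)Cc2cccc(C(=O)O)c2)c(C(F)(F)F)n1`, which in this assay gives 102%; together they hold the highest numbers of the three measured so far, and no change at the digits printed from compound 1 to compound 3 (within the scatter). Going by the values given here, the only lower number belongs to compound 2 `CC(C)c1onc(-c2c(Cl)cccc2Cl)c1COc1ccc(N(C)Cc2ccc(OCCO)cc2)c(C(F)(F)F)n1`, which in this assay gives 87%, and a number 15 percentage points lower from compound 1 to compound 2 (beyond the scatter).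

Compound 4 `O=C(O)c1cccc(OCc2ccc(OCc3c(-c4c(Cl)cccc4Cl)noc3C3CC3)nc2C(F)(F)F)c1` keeps the core of compound 3 and its 3-carboxyphenyl tail, but alters the link between core and tail: (3-carboxyphenoxy)methyl in place of (3-carboxybenzyl)(methyl)amino on an aromatic carbon. The change sits on an aromatic carbon of a six-membered aromatic ring with one nitrogen, ortho to a trifluoromethyl group, two atoms from the ring nitrogen, para to a large group.

Neither measured step bears directly on this change. The step from compound 1 to compound 2 concerns the tail itself, which compound 4 retains; the step from compound 1 to compound 3 concerns a distant group. Because compound 3 gives 102% and the tail is kept, compound 4 is expected to show a number 7 percentage points lower from compound 3 to compound 4 (within the scatter) in this assay. Compound 4 is therefore estimated at 95%, within a range from 70% to 115%.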

Compound 4, largest response reached (reported as efficacy), in percent of the reference or control that the assay uses: 98%
Beside the measured number, compound 4's estimate is 3 percentage points below it; the range from low to high includes it.
By their numbers in this assay, from the lowest: compound 2; then compounds 4, 1 and 3 (each within the scatter of the next).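

In this assay, the only change shown at this position, on an aromatic carbon of a six-membered aromatic ring with 1 nitrogen, ortho to a trifluoromethyl group, gives a number 4 percentage points lower from compound 3 to compound 4 (within the scatter) and stays inside the usual scatter. For the compounds shown here, on this read-out, (3-carboxyphenoxy)methyl and (3-carboxybenzyl)(methyl)amino cannot be told apart, so with this core and a 3-carboxyphenyl tail, a full maximal response does not require the nitrogen and its methyl group in the link, a point that the earlier steps, which changed only the tail or the distant cyclopropyl and isopropyl groups, could not address. The data at hand give no explanation for why the two links read alike.

The maximal response says nothing about the concentration needed to reach it, so the two links may still differ in potency. On these data alone, it also remains open whether a thioether or an amide in the link, or a longer chain between the core and the 3-carboxyphenyl tail, would hold the response, and whether the ether link would behave the same way with the 4-(2-hydroxyethoxy)phenyl tail.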